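Extending the Side Chain of Compound 1

The compounds below may be only part of what the source reports. "The series", "measured", "known", "first", "only" and "open" are said of these compounds alone.

Compound 1 `C/C=C/C(=O)Nc1cc2c(N3CCc4ccccc43)ncnc2cc1OC` was tested in a functional assay on MCF7 cells (Homo sapiens) for antiproliferative activity, read by MTT assay, with a stated time of 72 h (a higher number here means a weaker inhibitor, a lower number a stronger inhibitor), where compound 1 gives 4030 nM. Among the three measured compounds this is the lowest number. Compound 2 `C/C=C/C(=O)Nc1cc2c(N3CCc4ccccc43)ncnc2cc1O[C@@H]1CCOC1` gives 4900 nM in this assay, and the step of a 1.2-fold higher number from compound 1 to compound 2 (0.08 log units; within the scatter) exchanges one group for another on an oxygen of the shared core. Compound 3 `C/C=C/C(=O)Nc1cc2c(N3CCCc4ccccc43)ncnc2cc1OC` gives 12700 nM, a number that lies beyond the scatter from compound 1; the two differ only in the size of one ring.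

Compound 4 `COc1cc2ncnc(N3CCc4ccccc43)c2cc1NC(=O)/C=C/CN1CCN(C)CC1` differs from compound 1 by 4-methylpiperazin-1-yl in place of hydrogen on a saturated chain carbon bound to a double-bonded chain carbon, so that the prop-1-en-1-yl chain becomes 3-(4-methylpiperazin-1-yl)prop-1-en-1-yl. Neither measured step touches this chain: the change from compound 1 to compound 2 sits on the oxygen, and compound 3 differs in a ring, so nothing measured shows how the end of the chain responds. Within the data shown here, with no step bearing on it, the expectation for the step of a 1.2-fold lower number from compound 1 to compound 4 (0.06 log units; within the scatter) is one that stays within the scatter. Compound 4 is therefore expected to give about 3500 nM in this assay, within a range from 1200 nM to 10000 nM.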

Compound 4, half-maximal inhibitory concentration: 6430 nM
The estimate for compound 4 lay 1.8-fold (0.26 log units) below the measured number; the range from low to high includes it.
By their numbers in this assay, from the lowest: compounds 1, 2, 4 and 3 (each within the scatter of the next, the first and the last beyond it).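

The chain end of compound 1 had not been probed before, and this result gives the first reading there. In this assay, placing 4-methylpiperazin-1-yl on the saturated chain carbon bound to a double-bonded chain carbon gives a 1.6-fold higher number from compound 1 to compound 4 (0.20 log units; within the scatter), so this assay cannot tell the two compounds apart even though a whole ring-bearing group has replaced a single hydrogen. No measurement available here explains this result.

Still open, from the compounds shown here alone, is how this saturated chain carbon would respond to other groups, such as a small amine like dimethylamino, a morpholin-4-yl ring or a carboxylic acid, or to a longer chain carrying the same 4-methylpiperazin-1-yl group. Also open, going by these compounds, is whether the 3-(4-methylpiperazin-1-yl)prop-1-en-1-yl chain would read the same way on compound 2, with its oxolan-3-yl group on the oxygen, or on compound 3, with its larger ring.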